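Swapping Methoxy for Methyl on a Cytotoxicity Probe

The source may hold more compounds than are shown below. What is called first, only, known or untested is meant among the compounds shown, and "the series" means these compounds.

Compound 2 `COc1cc(Oc2ccnc(Nc3ccc(C#N)cc3)n2)ccc1-c1ccc(C#N)cc1` and compound 1 `N#Cc1ccc(Nc2nccc(Oc3ccc(-c4ccc(C#N)cc4)c(Cl)c3)n2)cc1` share one core and differ in a single group on an aromatic carbon. In a functional assay on MT4 cells (Homo sapiens) for cytotoxicity, read by MTT assay, with a stated time of 5 days (on this read-out higher numbers stand for lower toxicity in this test and lower numbers for higher toxicity in this test), compound 1 gives 31100 nM. For compound 2 the result in this assay is only a limit, > 298000 nM, so compound 2 stands at the edge of what the test can resolve, as shown by the limit of > 298000 nM in this assay, at which 1 of the 2 values shown sits. Going by the values given here, the one measured step, an at least 9.5-fold higher number from compound 1 to compound 2 (0.98 log units; beyond the scatter), is therefore known only as a lower bound and not as an exact size. Compound 3 `Cc1cc(Oc2ccnc(Nc3ccc(C#N)cc3)n2)ccc1-c1ccc(C#N)cc1` differs from compound 2 by methyl in place of methoxy on an aromatic carbon. Among the compounds with values here, no measured step concerns methyl directly; the only guidance is that chloro on this carbon sits at a measured number while methoxy sits at the limit. The outcome for methyl in this assay could fall anywhere between those two results, and the chance of another limit is real. The number for compound 3 is expected to be 100000 nM, with a plausible span from 25000 nM to 400000 nM. This would mean an estimated step of an at least 2.9-fold lower number from compound 2 to compound 3 (0.47 log units; beyond the scatter).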

Compound 3, half-maximal cytotoxic concentration: 29400 nM
Beside the measured number, compound 3's estimate is 3.4-fold (0.53 log units) above it; the measured number falls inside the stated range.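

In this assay, methyl on this aromatic carbon, ortho to a 4-cyanophenyl group, cannot be told apart from chloro: the comparison gives a 1.1-fold lower number from compound 1 to compound 3 (0.02 log units; within the scatter). Going from methoxy to methyl gives an at least 10-fold lower number from compound 2 to compound 3 (1.00 log units; beyond the scatter), a step beyond the scatter, so among these three groups the much higher number goes with methoxy alone, and the earlier result cannot be read as a general effect of replacing chloro. Going by these compounds, the exact size of this step stays unknown, and it can be read only as a minimum, because compound 2 sits at a limit of the test: the limit of > 298000 nM in this assay, at which 1 of the 3 values shown sits.

With only one oxygen-linked group shown on this carbon, it remains open whether the higher number belongs to methoxy in particular or would also appear with relatives such as ethoxy or hydroxyl, or with a nitrogen group such as an amine. Also open, on these data alone, is how far compound 2 truly lies from the other two compounds, and whether the same pattern among methyl, chloro and methoxy would hold at any other carbon of this ring.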